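The source may hold more compounds than are shown below. What is called first, only, known or untested is meant among the compounds shown, and "the series" means these compounds.

Measured compounds:
- compound 1 `NC1=NC2(CCSCC2)N(OCCCOc2ccc(Br)cc2)C(N)=N1`: > 90%
- compound 2 `NC1=NC2(CCSCC2)N(OCCCOc2ccccc2Cl)C(N)=N1`: 86.3%
- compound 3 `NC1=NC2(CCSCC2)N(OCCCOc2cccc(Br)c2)C(N)=N1`: 84.2%

All three share one core and differ only in the aryl group carried on an oxygen on a saturated carbon. In an assay on isolated protein for inhibition of Dihydrofolate reductase (Homo sapiens), read by spectrophotometry, using NADPH, with stated times of 5 s and 6 min, tested at 5 uM (a higher number here means a stronger effect of the compound at the concentration tested, a lower number a weaker effect), compound 1 reaches a limit of the assay, not a number (the limit of > 90% in this assay, at which 1 of the 3 values shown sits). Among the two numbers, compound 3 sits lowest, with compound 2 nearest; the step of a number 2.1 percentage points lower from compound 2 to compound 3 (within the scatter) lies within the scatter, so the two are not ordered. The steps of a number at least 3.7 percentage points lower from compound 1 to compound 2 (that floor lies within the scatter) and a number at least 5.8 percentage points lower from compound 1 to compound 3 (that floor lies within the scatter) have floors that also lie within the scatter, so none of the aryl exchanges so far has produced a step that can be called real.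

Compound 4 `COc1ccc(OCCCON2C(N)=NC(N)=NC23CCSCC3)cc1` is not yet measured. Compared with compound 3 the change is 4-methoxyphenyl in place of 3-bromophenyl on an oxygen on a saturated carbon. Among the compounds with values here, the steps that bear on it are the three aryl exchanges at the same place, all within the scatter; no measured step involves a methoxy group, so the expectation rests on the narrow spread of the series alone. The expected step of a number 2.2 percentage points lower from compound 3 to compound 4 (within the scatter) is therefore no change beyond the scatter. Compound 4 is estimated at 82%, in the range 65% to 92%.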

Compound 4, a percentage reported as inhibition, at one concentration (the size of the read-out at that concentration, not a potency): 81.3%
Compound 4: the middle estimate sits 0.7 percentage points above what was measured; low and high end bracket the measured number.
By their numbers in this assay, from the lowest: compounds 4, 3 and 2 (each within the scatter of the next). At a limit, above all of these: compound 1.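

Within the data shown here, replacing a halogen-bearing aryl group with 4-methoxyphenyl on an oxygen on a saturated carbon brings a hydrogen-bond acceptor into the aryl group for the first time, yet in this assay both steps between numbers stay within the scatter (a number 2.9 percentage points lower from compound 3 to compound 4 (within the scatter); a number 5 percentage points lower from compound 2 to compound 4 (within the scatter)). Methoxy in place of bromo on an aromatic carbon gives the widest floor seen so far at this place (a number at least 8.7 percentage points lower from compound 1 to compound 4 (that floor lies within the scatter)), but that floor also lies within the scatter, so the four aryl groups shown still yield no step that can be called real. Compound 1 stands at a limit of the assay, not at a number: the limit of > 90% in this assay, at which 1 of the 4 values shown sits.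

The compounds shown leave open whether an aryl group carrying an amine or a carboxylic acid, or a longer chain in place of the present saturated chain, would move the read-out beyond the scatter. As far as these compounds go, a read-out at one concentration also gives no potency for any of the four compounds, so whether they differ in potency remains open.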